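From compound 2 to compound 4: one group removed

The source may hold more compounds than are shown below. What is called first, only, known or untested is meant among the compounds shown, and "the series" means these compounds.

In a toxicity assay on cells (Cricetulus griseus) for cytotoxicity, read by MTT assay, with a stated time of 72 h (a lower number here means a stronger inhibitor, a higher number a weaker inhibitor), compound 2 `Cc1c(C)c2c(c(C)c1OC(=O)CCC(=O)O)CCC(C)(C(=O)NCC1CC(C)(C)N([O])C1(C)C)O2` reads > 300000 nM, which is a limit and not a number. Compound 1 `Cc1c(C)c2c(c(C)c1OC(=O)CCC(=O)O)CCC(C)(C(=O)NC1CC(C)(C)N([O])C(C)(C)C1)O2` reads > 300000 nM, which is also a limit. Compound 3 `Cc1c(C)c2c(c(C)c1O)CCC(C)(C(=O)NCC1CC(C)(C)N([O])C1(C)C)O2` gives 192000 nM, a true number. The picture so far is thus (the limit of > 300000 nM in this assay, at which 2 of the 3 values shown sit), so compound 2 offers a boundary to start from rather than a fixed point.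

Compound 4 `Cc1c(C)c2c(c(C)c1OC(=O)CCC(=O)O)CCC(C)(C(=O)O)O2` differs from compound 2 in one place: one oxygen atom in place of a group of 12 heavy atoms (9 carbon, 2 nitrogen, 1 oxygen; one five-membered non-aromatic ring with 1 hetero atom), on a carbonyl carbon. A hydroxy now stands on that carbonyl carbon, and the (2-carboxyethyl)carbonyl stays in place.

The measured evidence is thin. Exchanging the group on the amide-type nitrogen gave a step that the two limits leave unreadable from compound 1 to compound 2. Replacing the (2-carboxyethyl)carbonyl with hydrogen gave an at least 1.5-fold lower number from compound 2 to compound 3 (0.19 log units; that floor lies within the scatter). Neither step removes the group that leaves here, so neither gives a direct size for this change. Compound 1 and compound 2 both carry the (2-carboxyethyl)carbonyl, and both stop at the limit despite their different groups on the amide-type nitrogen. No clear move in either direction is therefore expected in this assay, and the expected change is a number no higher from compound 2 to compound 4 (the limit leaves the size open). For compound 4 the estimated value is 300000 nM, with an expected range from 150000 nM to 600000 nM.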

Compound 4, half-maximal inhibitory concentration: > 300000 nM
Compound 4: a limit, no number; the forecaster's own chance of this, stated with the estimate: 80%; the middle value lies on the limit itself.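

No new step can be read, because compound 4, like compound 1 and compound 2, stops at a limit and gives no number: the limit of > 300000 nM in this assay, at which 3 of the 4 values shown sit.

The compounds shown leave open whether the group on the carbonyl carbon matters at all in this assay, and how far any of the three compounds at the limit lies beyond it.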